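Trimethoxybenzyl Triazole Amide: Expected Growth Inhibition

This account rests on a few compounds, and the source may have more. Where it says the series, first, only, none or still open, it means among the compounds named here.

For the measured compounds named here, compound 2 `COc1ccc(Cn2cc(CNC(=O)c3cn(-c4ccccc4)nc3-c3ccc(OC)cc3)nn2)cc1` gives 22900 nM in a functional assay on MCF7 cells (Homo sapiens) for antiproliferative activity, read by sulforhodamine B assay, with a stated time of 48 h (a lower number here means a stronger inhibitor of growth, a higher number a weaker inhibitor of growth), the higher of the two numbers so far; compound 1 `COc1ccc(-c2nn(-c3ccccc3)cc2C(=O)NCc2cn(Cc3ccc(F)cc3)nn2)cc1` gives 460 nM in this assay. The change toward compound 3 `COc1ccc(-c2nn(-c3ccccc3)cc2C(=O)NCc2cn(Cc3cc(OC)c(OC)c(OC)c3)nn2)cc1` is 3,4,5-trimethoxyphenyl in place of 4-methoxyphenyl on a saturated chain carbon bound to an aromatic nitrogen. Going by the values given here, the only step that bears on this position is a 50-fold higher number from compound 1 to compound 2 (1.70 log units; beyond the scatter), a large loss on the same benzyl ring. Compound 3 is therefore expected to stay weak, with a modest step of a 1.5-fold lower number from compound 2 to compound 3 (0.18 log units; within the scatter) and no clear direction beyond the scatter. Compound 3 is estimated at 15000 nM, within 3000 nM to 60000 nM.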

Compound 3, concentration for 50% growth inhibition: 7600 nM
For compound 3 the middle estimate is 2.0-fold (0.30 log units) above the measured one; the measured number falls inside the stated range.
By their numbers in this assay, from the lowest: compound 1; then compound 3; then compound 2.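

At this saturated chain carbon bound to an aromatic nitrogen, more methoxy groups do not deepen the loss seen with the single methoxy: 3,4,5-trimethoxyphenyl in place of 4-methoxyphenyl gives a 3.0-fold lower number from compound 2 to compound 3 (0.48 log units; beyond the scatter) in this assay. The gain stays partial, since 3,4,5-trimethoxyphenyl in place of 4-fluorophenyl still gives a 17-fold higher number from compound 1 to compound 3 (1.22 log units; beyond the scatter). Nothing available explains either step.

The compounds shown leave open whether the partial recovery follows the number of methoxy groups, as a dimethoxybenzyl group could show. They also leave open how a benzyl ring carrying an amine or a carboxylic acid would read.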